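The source may report more compounds than this note shows. Statements on the series, on what has been measured and on what is new or still open speak of the compounds shown alone.

Measured compounds:
compound 1 `CCCCn1ccc(-c2ccc(Oc3cccnc3C)cc2)c(C#N)c1=O` — 347 nM
compound 2 `Cc1ncccc1Oc1ccc(-c2ccn(CC3CC3)c(=O)c2C#N)cc1` — 1070 nM

In a functional assay on CHO cells for positive allosteric modulation of metabotropic glutamate receptor 2 (Homo sapiens), read by scintillation counting and GTPgammaS binding, with a stated time of 30 min (a lower number here means that less compound is needed, a higher number that more compound is needed for the effect), compound 1 gives 347 nM, the lower of the two numbers recorded. Among the measured compounds shown here, compound 2 gives 1070 nM, and the one measured step, a 3.1-fold higher number from compound 1 to compound 2 (0.49 log units; beyond the scatter), concerns only the saturated chain bound to the aromatic nitrogen. Compound 3 `CCCCn1ccc(-c2ccc(Oc3cccnc3C)c(Cl)c2)c(C#N)c1=O` differs from compound 1 by chloro in place of hydrogen on an aromatic carbon. For the measured compounds named here, that change sits on a different part of the shared core from the one the measured step varies, so no measured step bears on it directly, and the two numbers recorded give no guide to what a chloro on this aromatic carbon does. With nothing to argue for a change in either direction, the step from compound 1 to compound 3 is expected to stay within the scatter, a 1.2-fold lower number from compound 1 to compound 3 (0.06 log units; within the scatter). Compound 3 is therefore estimated at 300 nM, with a range from 90 nM to 1000 nM to reflect the lack of a guiding step.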

Compound 3, half-maximal effective concentration: 100 nM
Estimate against measurement, compound 3: 3.0-fold (0.48 log units) above; measured number inside the range.
By their numbers in this assay, from the lowest: compound 3; then compound 1; then compound 2.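

Chloro in place of hydrogen on the aromatic carbon ortho to a (2-methylpyridin-3-yl)oxy group changes the result in this assay by more than the scatter (a 3.5-fold lower number from compound 1 to compound 3 (0.54 log units; beyond the scatter)). Among the compounds shown here, the earlier compounds differed only in the saturated chain on the aromatic nitrogen, so this is the first sign that the six-membered aromatic ring of carbon only also affects how much compound is needed, and that a single chlorine atom here reduces that amount. No measurement at hand accounts for the direction or size of this step.

From the compounds shown here alone, whether fluoro, bromo, methyl or methoxy on this same carbon would act as chloro does remains open, as does the effect of chloro on the other carbons of this ring. Also open, going by these compounds, is whether the same step would appear with the cyclopropyl chain of compound 2.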